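This account rests on a few compounds, and the source may have more. Where it says the series, first, only, none or still open, it means among the compounds named here.

In an ADME assay on NIH3T3 cells (Mus musculus) for cytotoxicity, read by MTT assay, with a stated time of 24 h (a higher number here means a weaker inhibitor, a lower number a stronger inhibitor), the measured compounds are:

- compound 1 `O=C(CSc1ncccn1)N/N=c1/scc(-c2ccc([N+](=O)[O-])cc2)n1-c1ccccc1` gives 193 ug/mL
- compound 2 `O=C(CSc1ncccn1)N/N=c1/scc(-c2ccccc2)n1-c1ccccc1` gives 107 ug/mL
- compound 3 `O=C(CSc1ncccn1)N/N=c1/scc(-c2ccc(F)cc2)n1-c1ccccc1` reaches only the assay limit of > 500 ug/mL

Among the two plain numbers, compound 2 and compound 1 lie within the scatter of each other: a 1.8-fold lower number from compound 1 to compound 2 (0.26 log units; within the scatter). The change to fluoro gives an at least 2.5-fold higher number from compound 1 to compound 3 (0.41 log units; beyond the scatter) and an at least 4.6-fold higher number from compound 2 to compound 3 (0.66 log units; beyond the scatter), both ending at a limit (the limit of > 500 ug/mL in this assay, at which 1 of the 3 values shown sits).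

Compound 4 `Cn1nnnc1SCC(=O)N/N=c1/scc(-c2ccccc2)n1-c1ccccc1` differs from compound 2 elsewhere: 1-methyl-1H-tetrazol-5-yl in place of pyrimidin-2-yl on a sulfur. All three measured steps concern the group on the aromatic ring, not the group on the sulfur, so none of them shows what this exchange does in this assay. Within the data shown here, with no measured step on the sulfur side, the plain expectation is no step beyond the scatter. Compound 4 is therefore estimated at 110 ug/mL, with a range from 40 ug/mL to 320 ug/mL. The step that this estimate means is expected to be a 1.0-fold higher number from compound 2 to compound 4 (0.01 log units; within the scatter).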

Compound 4, half-maximal inhibitory concentration: 173 ug/mL
The estimate for compound 4 lay 1.6-fold (0.20 log units) below the measured number; low and high end bracket the measured number.
By their numbers in this assay, from the lowest: compounds 2, 4 and 1 (each within the scatter of the next). At a limit, above all of these: compound 3.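

On the sulfur, the exchange gives in this assay a 1.6-fold higher number from compound 2 to compound 4 (0.21 log units; within the scatter), so the two compounds cannot be told apart, even though a five-membered aromatic ring with 4 hetero atoms replaces a six-membered one with 2. Among these compounds, the earlier compounds varied only the group on the aromatic ring, so this is the first reading of the sulfur side, and this one exchange produces no step beyond the scatter. Nothing measured here offers an explanation for this result.

From the compounds shown here alone, one exchange is a single point, so it remains open whether other groups on the sulfur, such as an amine, a carboxylic acid or a longer chain, would also stay within the scatter. Also open, going by these compounds, is whether 1-methyl-1H-tetrazol-5-yl would read the same with fluoro or nitro on the aromatic ring.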